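A few compounds are considered here, and "the series" means these few. Any claim that something is new, unique, unknown or untested is made for them only; others in the source may bear on it.

Three compounds measured in a functional assay, read by spectrophotometry, with a stated time of 30 min; a lower number here means that less compound is needed, a higher number that more compound is needed for the effect:

Compound 1 `O=C(/C=C/c1ccc(O)c(O)c1)Nc1ccccc1Sc1ccccc1`: 27000 nM
Compound 2 `CC(C)(C)c1ccc(O)c(NC(=O)/C=C/c2ccc(O)c(O)c2)c1`: 11900 nM
Compound 3 `CC(=O)c1cccc(NC(=O)/C=C/c2ccc(O)c(O)c2)c1`: 10600 nM

In this assay, compound 2 at 11900 nM lies within the usual scatter of compound 3 at 10600 nM. Compound 1 at 27000 nM stands clearly higher than compound 2, beyond the scatter.

The next compound is compound 4 `Cc1ccc(O)c(NC(=O)/C=C/c2ccc(O)c(O)c2)c1`. It matches compound 2 except for methyl in place of tert-butyl on an aromatic carbon, para to a hydroxy group (methyl in place of tert-butyl on an aromatic carbon).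

Among the measured compounds shown here, no two measured compounds differ in just one place, which leaves no direct guide to this change. For the measured compounds named here, the only evidence is the small spread of the values so far, from compound 3 at 10600 nM to compound 1 at 27000 nM. On that basis, no clear rise or fall is expected, and the estimated step of a 1.0-fold higher number from compound 2 to compound 4 (0.00 log units; within the scatter) should stay within the scatter. The estimate for compound 4 is 12000 nM, with an expected range of 5500 nM to 27000 nM.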

Compound 4, half-maximal effective concentration: 6570 nM
Estimate against measurement, compound 4: 1.8-fold (0.26 log units) above; measured number inside the range.
By their numbers in this assay, from the lowest: compounds 4, 3 and 2 (each within the scatter of the next); then compound 1.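

Among the compounds shown here, this is the first pair in the set that differs in only one place, so it gives a direct look at the aromatic carbon para to a hydroxy group. In this assay, methyl in place of tert-butyl gives a 1.8-fold lower number from compound 2 to compound 4 (0.26 log units; within the scatter) and so stays within the usual scatter, which means that going from 4 heavy atoms to 1 at this position makes no clear difference for this pair. No measurement shown here explains this result.

The compounds shown leave open whether a different kind of group at this position, such as an amine or a carboxylic acid, would move the number beyond the scatter. They also leave open what a plain hydrogen there would give, with the rest of the molecule unchanged.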